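Cytotoxicity notes on the shared-core series, compound 3

The compounds below may be only part of what the source reports. "The series", "measured", "known", "first", "only" and "open" are said of these compounds alone.

Measured so far:
compound 1 `COc1cc2c(cc1OC)CN(S(=O)(=O)c1ccc(-n3cc(COc4ccc([N+](=O)[O-])cc4)nn3)cc1)CC2` — > 50 ug/mL, a limit of the assay
compound 2 `COc1cc2c(cc1OC)CN(S(=O)(=O)c1ccc(-n3cc(COc4cc(C=O)ccc4OC)nn3)cc1)CC2` — > 50 ug/mL, a limit of the assay

In an ADME assay on Vero cells (Chlorocebus sabaeus) for cytotoxicity, with a stated time of 4 days (on this read-out lower numbers stand for stronger inhibition and higher numbers for weaker inhibition), compound 1 reaches only a limit, > 50 ug/mL. In this assay compound 2 likewise reaches only a limit, > 50 ug/mL. Among the compounds with values here, the one measured step, a step that the two limits leave unreadable from compound 1 to compound 2, is therefore unreadable: both values sit at the limit of > 50 ug/mL in this assay, at which 2 of the 2 values shown sit, and the size of the step cannot be taken from them. Compound 2 thus stands at the limit, with no number of its own.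

Compound 3 `COc1cc2c(cc1OC)CN(S(=O)(=O)c1ccc(-n3cc(CO)nn3)cc1)CC2` differs from compound 2 by hydrogen in place of 5-formyl-2-methoxyphenyl on an oxygen on a saturated carbon. Within the data shown here, the only step measured, from compound 1 to compound 2, changed the same position and stayed at the limit; no step with a readable size bears on the change to compound 3. The expectation is therefore no step beyond the scatter, a number no higher from compound 2 to compound 3 (the limit leaves the size open), and compound 3 is estimated to report a limit again. Compound 3 is expected at 50 ug/mL, with a range from 25 ug/mL to 100 ug/mL.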

Compound 3, half-maximal inhibitory concentration: > 50 ug/mL
Compound 3 gave a limit, no number (the forecaster's own chance of this, stated with the estimate: 80%); the middle value sits exactly at the limit.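

In this assay compound 3 gives > 50 ug/mL, a limit of the assay and not a number. No step among compound 1, compound 2 and compound 3 can be read, since all three sit at the same limit: the limit of > 50 ug/mL in this assay, at which 3 of the 3 values shown sit.

The compounds shown leave open where their actual values lie and whether any group on this oxygen would give a readable number.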